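The source may hold more compounds than are shown below. What is called first, only, known or untested is meant among the compounds shown, and "the series" means these compounds.

Compound 1 `O=C(C(Nc1ccccc1F)c1ccc(C(F)(F)F)cc1)N1CCCC1c1ccccc1Cl` is the stronger of the two measured compounds in an assay on HEK293 cells for antagonist activity at transient receptor potential M8 protein (Canis lupus familiaris), read by fluorescence and calcium flux, with a stated time of 5 min; a lower number here means a stronger inhibitor, a higher number a weaker inhibitor: compound 1 gives 11 nM, the lowest of the two numbers, while compound 2 `O=C(C(Nc1cccc(F)c1)c1ccc(C(F)(F)F)cc1)N1CCCC1c1ccccc1Cl` gives 138 nM. Within the data shown here, the one measured step, a 13-fold higher number from compound 1 to compound 2 (1.10 log units; beyond the scatter), concerns the fluorophenyl on the amine nitrogen and leaves the group on the saturated ring carbon untouched. Compound 3 `O=C(O)c1cccc(C2CCCN2C(=O)C(Nc2ccccc2F)c2ccc(C(F)(F)F)cc2)c1` differs from compound 1 elsewhere: 3-carboxyphenyl in place of 2-chlorophenyl on a saturated ring carbon. Among the measured compounds shown here, no measured step touches that saturated ring carbon, so the data give no direct guide to this change. For the measured compounds named here, the single step seen does show that one change on this core can move the number by a large step, so a shift beyond the scatter is plausible here too. With a group carrying 1 hydrogen-bond donor and 1 hydrogen-bond acceptor entering in place of 2-chlorophenyl, a weaker number is expected for compound 3, a 23-fold higher number from compound 1 to compound 3 (1.36 log units; beyond the scatter). Compound 3 is estimated at 250 nM, within 30 nM to 2500 nM.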

Compound 3, half-maximal inhibitory concentration: 40 nM
Compound 3: the middle estimate sits 6.3-fold (0.80 log units) above what was measured; the range from low to high includes it.
By their numbers in this assay, from the lowest: compound 1; then compound 3; then compound 2.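

Among these compounds, this is the first reading at the saturated ring carbon next to the ring nitrogen: in this assay the exchange of 2-chlorophenyl for 3-carboxyphenyl gives a 3.6-fold higher number from compound 1 to compound 3 (0.56 log units; beyond the scatter) and so lies beyond the scatter, though only as a modest step. The position therefore accepts a group with 1 hydrogen-bond donor and 1 hydrogen-bond acceptor at a smaller cost than the large step on the amine nitrogen (a 13-fold higher number from compound 1 to compound 2 (1.10 log units; beyond the scatter)). Nothing given here explains why the number moves.

The compounds shown leave open how an unsubstituted phenyl, a 3-chlorophenyl or a 3-carbamoylphenyl would read at this carbon. They also leave open whether 3-fluorophenyl on the amine nitrogen would cost as much alongside 3-carboxyphenyl.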